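Fluoro to pyrrolidin-1-yl: what happens to compound 2?

This account rests on a few compounds, and the source may have more. Where it says the series, first, only, none or still open, it means among the compounds named here.

For the measured compounds named here, in a functional assay on SNU-638 cells (Homo sapiens) for cytotoxicity, read by MTT assay (on this read-out lower numbers stand for stronger inhibition and higher numbers for weaker inhibition), compound 2 `O=C(/C=C/c1ccc(F)cc1)c1ccc(O)cc1O` gives 9430 nM and holds the higher of the two true numbers measured so far. Compound 1 `O=C(/C=C/c1ccc(N2CCCC2)cc1)c1ccc(O)cc1` gives 620 nM and holds the lower one. Compound 3 `COc1cc(O)ccc1C(=O)/C=C/c1ccc(F)cc1` reaches only a limit of the assay, > 25000 nM and no true number.

One measured step involves a single change, methyl in place of hydrogen on an oxygen on an aromatic ring, and it gives an at least 2.6-fold higher number from compound 2 to compound 3 (0.42 log units; beyond the scatter) as its result. That step shows that a small change can move the number beyond the scatter, but it says little about the change considered here, which lies elsewhere.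

Compound 4 `O=C(/C=C/c1ccc(N2CCCC2)cc1)c1ccc(O)cc1O` differs from compound 2 by pyrrolidin-1-yl in place of fluoro on an aromatic carbon with pyrrolidin-1-yl in place of fluoro on an aromatic carbon. Going by the values given here, no measured step covers this exchange directly. The best guide is compound 1, which also carries pyrrolidin-1-yl and gives 620 nM in this assay as a much lower number than the fluoro compounds show. A clear move toward stronger inhibition, beyond the scatter, is therefore expected, and the estimated change is a 12-fold lower number from compound 2 to compound 4 (1.07 log units; beyond the scatter) on this read-out. Among the compounds with values here, with only one compound as a guide, the range stays wide. For compound 4 the expected value is 800 nM within an estimated range from 200 nM to 3000 nM in this read-out.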

Compound 4, half-maximal inhibitory concentration: 5770 nM
Compound 4: the middle estimate sits 7.2-fold (0.86 log units) below what was measured, and the stated range ends below it.
By their numbers in this assay, from the lowest: compound 1; then compounds 4 and 2 (each within the scatter of the next). At a limit, above all of these: compound 3.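

In this assay, putting pyrrolidin-1-yl in place of fluoro at this spot, on an aromatic carbon para to a large group, gives a 1.6-fold lower number from compound 2 to compound 4 (0.21 log units; within the scatter), so on this evidence the two groups cannot be told apart here when the rest of the molecule is that of compound 2. The low number of compound 1 therefore does not come with pyrrolidin-1-yl alone: hydroxy in place of hydrogen on an aromatic carbon gives a 9.3-fold higher number from compound 1 to compound 4 (0.97 log units; beyond the scatter), a modest step but one beyond the scatter, and it shows that the surroundings of the exchanged group matter in this small set. Nothing measured among these compounds gives a reason for either step.

Going by these compounds, whether fluoro and pyrrolidin-1-yl would also read alike on the core of compound 1, without that extra hydroxy, stays open. Also open, on these data alone, is how this assay would respond at this spot to groups of a different kind, such as an open-chain amine like dimethylamino or a carboxylic acid.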